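The source may hold more compounds than are shown below. What is called first, only, known or untested is meant among the compounds shown, and "the series" means these compounds.

Measured in an ADME assay on BJ cells (Homo sapiens) for cytotoxicity, read by luminescence, with a stated time of 72 h; on this read-out higher numbers stand for an effect only at larger amounts of compound and lower numbers for an effect already at smaller amounts:
- Compound 1 `CCOC(=O)c1c(-c2cccc(OC(F)(F)F)c2)[nH]c2cc(OC)ccc2c1=O`: > 21500 nM, a limit
- Compound 2 `CCOC(=O)c1c(-c2cccc(-c3ccccc3)c2)[nH]c2cc(OC)c(OC)cc2c1=O`: > 21500 nM, a limit
- Compound 3 `CCOC(=O)c1c(-c2cccc(OC(F)(F)F)c2)[nH]c2cc(OC)c(F)cc2c1=O`: > 21500 nM, a limit

Compound 3 gives no number, only a limit, and stands with the rest of the series at the limit of > 21500 nM in this assay, at which 3 of the 3 values shown sit.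

The next compound is compound 4 `CCOC(=O)c1c(-c2cccc(-c3c(C)cccc3C)c2)[nH]c2cc(OC)c(F)cc2c1=O`, and the change from compound 3 is 2,6-dimethylphenyl in place of trifluoromethoxy on an aromatic carbon. In words, 2,6-dimethylphenyl takes the place of trifluoromethoxy on an aromatic carbon, meta to a large group.

For the measured compounds named here, the only measured step is a step that the two limits leave unreadable from compound 1 to compound 3. It concerns fluoro in place of hydrogen, so it gives no size for this exchange. The nearest guide is compound 2, which carries a phenyl group where compound 3 carries trifluoromethoxy, though it also differs elsewhere on the core. Compound 2 shows > 21500 nM, which is again a limit.

Going by the values given here, no measured compound therefore shows a readable effect in this assay, and no direction can be drawn from these data. The expected step is a number no higher from compound 3 to compound 4 (the limit leaves the size open), with nothing expected beyond the scatter. A reading at the same limit is the most likely outcome. For compound 4 the estimate is 21500 nM, with an expected range of 10000 nM to 40000 nM.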

Compound 4, half-maximal effective concentration: > 21500 nM
Compound 4: only a limit was reported; the forecaster's own chance of this, stated with the estimate: 85%; the middle value lies on the limit itself.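

In this assay compound 4 gives > 21500 nM, which is a limit. Compound 3 also stands at a limit, so the step between compound 3 and compound 4 cannot be read. The compounds shown leave open whether 2,6-dimethylphenyl in place of trifluoromethoxy shifts the read-out at all, and at what concentration any compound of the series would show an effect, with every value at one limit: the limit of > 21500 nM in this assay, at which 4 of the 4 values shown sit.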